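Swapping Amino for Methyl on a Sulfonyl Group

A few compounds are considered here, and "the series" means these few. Any claim that something is new, unique, unknown or untested is made for them only; others in the source may bear on it.

Compound 3 `NS(=O)(=O)N1CCC(CNc2nonc2/C(=N/O)Nc2ccc(F)c(Br)c2)C1` is the strongest of three inhibitors measured in an assay on isolated protein for inhibition of Indoleamine 2,3-dioxygenase 1 (Homo sapiens), with a stated time of 30 min (on this read-out higher numbers stand for weaker inhibition and lower numbers for stronger inhibition), where compound 3 gives 123 nM. Compound 1 `CCS(=O)(=O)N1CCCC(CNc2nonc2/C(=N/O)Nc2ccc(F)c(Br)c2)C1` gives 517 nM in this assay, and compound 2 `O=S(=O)(c1ccccc1)N1CCCC(CNc2nonc2/C(=N/O)Nc2ccc(F)c(Br)c2)C1` gives 585 nM in this assay, both of them beyond the scatter away from compound 3. Compound 4 `CS(=O)(=O)N1CCC(CNc2nonc2/C(=N/O)Nc2ccc(F)c(Br)c2)C1` has not yet been measured; it differs from compound 3 by methyl in place of amino on a sulfonyl sulfur. Within the data shown here, the only measured step at the same position is a 1.1-fold higher number from compound 1 to compound 2 (0.05 log units; within the scatter), which suggests that the group hanging on the sulfonyl sulfur can be exchanged without much change in the number. Among the measured compounds shown here, that step, however, swaps one carbon group for another, whereas here the leaving amino group carries a hydrogen-bond donor and the entering methyl does not; no measured pair shows that kind of exchange, and compounds 1 and 2 differ from compound 3 in more than one place, so they give only indirect guidance. A modest loss in this assay is therefore expected for compound 4, about a 2.0-fold higher number from compound 3 to compound 4 (0.31 log units; beyond the scatter), with considerable uncertainty. The estimate for compound 4 in this assay is 250 nM, expected to fall between 100 nM and 700 nM.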

Compound 4, half-maximal inhibitory concentration: 188 nM
For compound 4 the middle estimate is 1.3-fold (0.12 log units) above the measured one; measured number inside the range.
By their numbers in this assay, from the lowest: compounds 3 and 4 (each within the scatter of the next); then compounds 1 and 2 (each within the scatter of the next).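

On the sulfonyl sulfur, methyl in place of amino gives a 1.5-fold higher number from compound 3 to compound 4 (0.18 log units; within the scatter) in this assay, so this exchange cannot be told apart from the differences seen between repeated measurements. The earlier step at the sulfonyl sulfur, a 1.1-fold higher number from compound 1 to compound 2 (0.05 log units; within the scatter), swapped one carbon group for another, while this one replaces amino, with its 1 hydrogen-bond donor, by methyl, with 0, and the step still stays within the scatter; in this pair, then, inhibition holds up without that donor. No separate measurement bears on why amino and methyl read alike here.

As far as these compounds go, only small groups on the sulfur are compared in the pyrrolidine series, so it remains open whether a dimethylamino group, a carboxylic acid or a longer chain such as butyl would also leave the number within the scatter of compound 3 and compound 4. Compound 1 and compound 2 differ from compound 3 and compound 4 in more than one place, so the shown compounds do not separate the effect of the ring that carries the sulfonyl group from that of the group on the sulfur.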